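A Nitro for Trifluoromethyl on the Anilino Ring

The source may report more compounds than this note shows. Statements on the series, on what has been measured and on what is new or still open speak of the compounds shown alone.

Compound 1, `CC(C)c1ccc(-c2nc(SCc3cn(CC(=O)NC(=O)Nc4ccccn4)nn3)nc(Nc3ccc(F)cc3)c2C#N)cc1`, gives 17500 nM in a functional assay on MGC-803 cells (Homo sapiens) for inhibition, read by MTT assay, with a stated time of 72 h; on this read-out lower numbers stand for stronger inhibition and higher numbers for weaker inhibition.
Compound 2, `CC(C)c1ccc(-c2nc(SCc3cn(CC(=O)NC(=O)Nc4ccccn4)nn3)nc(Nc3ccc(Cl)cc3)c2C#N)cc1`, is reported in this assay only as a limit, > 64000 nM.
Compound 3, `CC(C)c1ccc(-c2nc(SCc3cn(CC(=O)NC(=O)Nc4ccccn4)nn3)nc(Nc3cccc(C(F)(F)F)c3)c2C#N)cc1`, is likewise reported in this assay only as a limit, > 64000 nM.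

Compound 3 therefore stands at the limit of > 64000 nM in this assay, at which 2 of the 3 values shown sit, and its value is not a number. The step of an at least 3.6-fold higher number from compound 1 to compound 3 (0.56 log units; beyond the scatter) carried the series to that limit, while a step that the two limits leave unreadable from compound 2 to compound 3 cannot be read. Compound 4, `CC(C)c1ccc(-c2nc(SCc3cn(CC(=O)NC(=O)Nc4ccccn4)nn3)nc(Nc3cccc([N+](=O)[O-])c3)c2C#N)cc1`, differs from compound 3 by nitro in place of trifluoromethyl on an aromatic carbon. No measured pair exchanges these two groups, so the steps shown give no direction for this change, and the starting point is itself only a limit. Compound 4 is expected to sit in the same weak region, estimated at 50000 nM (15000 nM to 130000 nM). That estimate means an expected step of an at least 1.2-fold lower number from compound 3 to compound 4 (0.10 log units; that floor lies within the scatter), with a real chance that only a limit is reported again.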

Compound 4, half-maximal inhibitory concentration: > 64000 nM
Compound 4 ended at the assay's limit; the forecaster's own chance of this, stated with the estimate: 50%; middle value at least 1.2-fold (0.10 log units) from the limit.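

In this assay, compound 4 is also reported only as a limit, > 64000 nM, so nitro, like trifluoromethyl, gives no number on this ring. Going by these compounds alone, the one readable step is an at least 3.6-fold higher number from compound 1 to compound 4 (0.56 log units; beyond the scatter), for 3-nitrophenyl in place of 4-fluorophenyl, while the steps from compound 2 and from compound 3 to compound 4 cannot be read. Compound 1 is now the only one of the four with a number, and the other three share one limit: the limit of > 64000 nM in this assay, at which 3 of the 4 values shown sit.

Going by these compounds, whether nitro and trifluoromethyl differ at all beyond that limit remains open. Also open, on these data alone, is whether an amine or a carboxylic acid on the anilino ring would give a number, as compound 1 does.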